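The compounds below may be only part of what the source reports. "The series", "measured", "known", "first", "only" and "open" are said of these compounds alone.

Measured compounds:
Compound 1, `O=C1O[C@H]([C@@H](O)Cn2cc(-c3cc(F)cc(F)c3)nn2)C(OCc2ccccc2)=C1OCc1ccccc1`: 41200 nM
Compound 2, `O=C1O[C@H]([C@@H](O)Cn2cc(CNS(=O)(=O)c3ccc(Cl)cc3F)nn2)C(OCc2ccccc2)=C1OCc1ccccc1`: 39100 nM

Of the compounds shown here, two have been tested in a functional assay on A549 cells (Homo sapiens) for antiproliferative activity, read by MTT assay, with a stated time of 72 h; on this read-out lower numbers stand for stronger inhibition and higher numbers for weaker inhibition. Compound 1 carries a difluorophenyl on its triazole and gives 41200 nM. Compound 2 instead carries a sulfonamide-bearing chain on the same ring and gives 39100 nM. The two numbers sit within the usual scatter of each other, so compound 2 cannot be set apart from compound 1 in this assay: both are weak, and the rather different groups on the triazole have not changed the read-out beyond noise.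

Compound 3, `O=C1O[C@H]([C@@H](O)Cn2cc(CCO)nn2)C(OCc2ccccc2)=C1OCc1ccccc1`, has not yet been measured. Relative to compound 2 the change is hydroxymethyl in place of ((4-chloro-2-fluorophenyl)sulfonyl)amino on a saturated chain carbon bound to an aromatic carbon. The shared core, with its two benzyl ethers and the hydroxyl-bearing side chain, is kept; only the tail of the triazole is cut back to a small hydroxymethyl.

Among the measured compounds shown here, with no measured step to lean on, and given that compound 1 and compound 2 agree within scatter despite differing tails, the expectation for compound 3 is a step of a 1.3-fold higher number from compound 2 to compound 3 (0.11 log units; within the scatter), that is little movement beyond the scatter, if anything towards a weaker read-out. Compound 3 is therefore estimated at 50000 nM, in the range 20000 nM to 150000 nM.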

Compound 3, half-maximal inhibitory concentration: > 100000 nM
Compound 3: only a limit was reported; the forecaster's own chance of this, stated with the estimate: 20%; at least 2.0-fold (0.30 log units) between middle value and limit.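

In this assay, compound 1 and compound 2 could not be told apart despite their very different tails, which made this position look indifferent to what it carries, yet cutting the tail back does register: hydroxymethyl in place of ((4-chloro-2-fluorophenyl)sulfonyl)amino on a saturated chain carbon bound to an aromatic carbon gives an at least 2.5-fold higher number from compound 2 to compound 3 (0.40 log units; beyond the scatter). The comparison with the other tail points the same way, since 2-hydroxyethyl in place of 3,5-difluorophenyl on an aromatic carbon gives an at least 2.4-fold higher number from compound 1 to compound 3 (0.38 log units; beyond the scatter), so the two tails that hold a six-membered aromatic ring both read lower than the small tail without one. The true size of both steps stays unknown, because compound 3 is reported only as a limit and not as a number: the limit of > 100000 nM in this assay, at which 1 of the 3 values shown sits.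

The compounds shown leave open whether the aromatic ring itself counts or whether any sizeable tail would do, and a plain phenyl or benzyl on the triazole would help separate the two. They also leave open whether the hydroxyl of compound 3 plays any part, which a simple ethyl chain or an amine in its place could test.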